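This account rests on a few compounds, and the source may have more. Where it says the series, first, only, none or still open, it means among the compounds named here.

The set rests on two cores. Compound 1 `CC(C)(C)OC(=O)/C(C#N)=C/c1ccoc1` and compound 2 `CC(C)CCOC(=O)/C(C#N)=C/c1ccoc1` share one core, while compound 3 `CC(C)(C)OC(=O)/C(C#N)=C/c1cc2ccccc2[nH]1` and the not yet measured compound 4 `CC(C)CCOC(=O)/C(C#N)=C/c1cc2ccccc2[nH]1` share the other. The difference between the two cores is not broken down here.

In a functional assay on the whole organism (strain CD1) for inhibition, with Mus musculus as the target, with stated times of 15 min and 20 min, at a dose of 10 mg/kg by the subcutaneous route (a higher number here means more inhibition at the dose given (going by the name of the read-out), a lower number less inhibition), compound 1 gives 81.8%. Compound 2 differs from compound 1 by one change, (isopentyl in place of tert-butyl on an oxygen next to a carbonyl group), and in this assay compound 2 gives 82.2%. The step is a number 0.4 percentage points higher from compound 1 to compound 2 (within the scatter), so the two numbers cannot be told apart.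

On the second core, compound 3 gives 51.3% in this assay, a number that lies beyond the scatter below both compound 1 and compound 2.

Compound 4 stands to compound 3 as compound 2 stands to compound 1: isopentyl in place of tert-butyl on an oxygen next to a carbonyl group. The place of the change is word for word the same as in the first pair, so it is the same change carried onto the other core. For compound 4 the step is expected to be a number 0.7 percentage points higher from compound 3 to compound 4 (within the scatter), an expectation that rests on the first pair, where the same change gave a number 0.4 percentage points higher from compound 1 to compound 2 (within the scatter). On that basis compound 4 is estimated to give 52% in this assay, with a likely range from 38% to 66%.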

Compound 4, a percentage reported as inhibition, in the whole organism at one dose (the size of the read-out at that dose, not a potency): 46.6%
Compound 4: middle estimate off by 5.4 percentage points, on the high side, within the range that was stated.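

In this assay, the change from tert-butyl to isopentyl on the second core gives a number 4.7 percentage points lower from compound 3 to compound 4 (within the scatter), so the two numbers on that core cannot be told apart, and the step does not differ measurably from the one on the first core: the same change on two cores in this assay, a number 0.4 percentage points higher (within the scatter) from compound 1 to compound 2 and a number 4.7 percentage points lower (within the scatter) from compound 3 to compound 4, 5.1 percentage points apart, within the scatter of two such steps. In this series, then, the change carries from one core to the other without a detectable difference, and on neither core does it move the read-out by more than the usual scatter. Within the data shown here, this does not show that the two groups are equivalent in general, since it rests on only two pairs, at a single dose and in a single assay, and a small real effect of the change on either core could lie hidden within the scatter of such steps.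

The compounds shown carry only tert-butyl and isopentyl on that oxygen, so it remains open how a longer straight chain, a benzyl group or a free carboxylic acid in that place would behave in this assay. As far as these compounds go, it also remains open which part of the difference between the two cores goes with the lower numbers on the second core, as the cores are not broken down into single changes here.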